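Moving the trifluoromethyl group: compound 3 to compound 4

This account rests on a few compounds, and the source may have more. Where it says the series, first, only, none or still open, it means among the compounds named here.

Measured in a functional assay on HeLa cells (Homo sapiens) for inhibition, read by MTT assay, with a stated time of 72 h; on this read-out lower numbers stand for stronger inhibition and higher numbers for weaker inhibition:
compound 1 `COc1cc(NC(C)CCCNC(=O)Nc2ccc(F)cc2)c2ncccc2c1` gives 20000 nM
compound 2 `COc1cc(NC(C)CCCNC(=O)Nc2cc(C(F)(F)F)cc(C(F)(F)F)c2)c2ncccc2c1` gives 3100 nM
compound 3 `COc1cc(NC(C)CCCNC(=O)Nc2ccc(C(F)(F)F)cc2)c2ncccc2c1` gives 8300 nM

Compound 3 at 8300 nM stands second highest of the three, with compound 1 higher and compound 2 lower. Compound 4 `COc1cc(NC(C)CCCNC(=O)Nc2cccc(C(F)(F)F)c2)c2ncccc2c1` carries 3-(trifluoromethyl)phenyl in place of 4-(trifluoromethyl)phenyl on an amide-type nitrogen. Among the measured compounds shown here, no measured step isolates this change. The nearest guide is the modest 2.4-fold lower number from compound 1 to compound 3 (0.38 log units; beyond the scatter) for a change of group on the aromatic ring. A step no larger than that is expected, slightly downward or none beyond the scatter, as an estimated 1.2-fold lower number from compound 3 to compound 4 (0.07 log units; within the scatter) in size. In this assay compound 4 is estimated at 7000 nM (3500 nM to 14000 nM).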

Compound 4, half-maximal inhibitory concentration: 14000 nM
Compound 4: the middle estimate sits 2.0-fold (0.30 log units) below what was measured; low and high end bracket the measured number.
By their numbers in this assay, from the lowest: compound 2; then compounds 3, 4 and 1 (each within the scatter of the next, the first and the last beyond it).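

In this assay, 3-(trifluoromethyl)phenyl in place of 4-(trifluoromethyl)phenyl on the amide-type nitrogen gives a 1.7-fold higher number from compound 3 to compound 4 (0.23 log units; within the scatter) and so does not separate the two groups. The exchange of 4-fluorophenyl for 3-(trifluoromethyl)phenyl gives a 1.4-fold lower number from compound 1 to compound 4 (0.15 log units; within the scatter) and likewise shows no separation. Hydrogen in place of one trifluoromethyl group gives a 4.5-fold higher number from compound 2 to compound 4 (0.65 log units; beyond the scatter) as the only step here beyond the scatter, so the second trifluoromethyl group matters more than the location of a single one. As far as these compounds go, how a nitrile or an amine on this ring would compare remains open. Nothing available explains these steps.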